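Cyano for fluoro on the distal phenyl of compound 2

This account rests on a few compounds, and the source may have more. Where it says the series, first, only, none or still open, it means among the compounds named here.

Measured compounds:
compound 1, `CN1CCN(Cc2csc(N)c2C(=O)c2ccc(Cl)cc2)CC1` — 1.2 nM
compound 2, `Nc1scc(CN2CCN(c3ccc(F)cc3)CC2)c1C(=O)c1ccc(Cl)cc1` — 1 nM

In an assay on CHO cells for displacement of a labelled ligand from adenosine receptor A1 (Homo sapiens) (a higher number here means weaker binding, a lower number tighter binding), compound 1 gives 1.2 nM, and compound 2 gives 1 nM. For the measured compounds named here, the two sit together: the only measured step, a 1.2-fold lower number from compound 1 to compound 2 (0.08 log units; within the scatter), lies within the scatter, so compound 2 cannot be set apart from compound 1 on these numbers. Compound 3, `N#Cc1ccc(N2CCN(Cc3csc(N)c3C(=O)c3ccc(Cl)cc3)CC2)cc1`, has not yet been measured in this assay. It differs from compound 2 in one place: cyano in place of fluoro on an aromatic carbon. Going by the values given here, no measured step exchanges one substituent on that six-membered aromatic ring of carbon only for another, so nothing bears on this change directly. Among the compounds with values here, the one step that exists, a 1.2-fold lower number from compound 1 to compound 2 (0.08 log units; within the scatter), shows that a large change at the amine nitrogen in a ring, from methyl to 4-fluorophenyl, left the number where it was. On that basis a small exchange at the far end of that same 4-fluorophenyl is expected to move the number little, if at all, beyond the scatter. For compound 3 the estimate is 1.5 nM, between 0.4 nM and 6 nM. The step so expected is a 1.5-fold higher number from compound 2 to compound 3 (0.18 log units; within the scatter).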

Compound 3, dissociation constant: 1.1 nM
Compound 3: middle estimate off by 1.4-fold (0.13 log units), on the high side, and the stated range covers the measured number.
By their numbers in this assay, from the lowest: compounds 2, 3 and 1 (each within the scatter of the next).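

In this assay, for the compounds shown here, cyano in place of fluoro gives a 1.1-fold higher number from compound 2 to compound 3 (0.04 log units; within the scatter) and so provides the first direct reading of one substituent exchanged for another on this aromatic carbon, para to a large group, where two heavy atoms, a triple bond and a hydrogen-bond acceptor enter and one fluorine leaves without separating the two compounds. The further step, a 1.1-fold lower number from compound 1 to compound 3 (0.04 log units; within the scatter), adds a second aryl group to the comparison with methyl on the amine nitrogen in a ring, so neither 4-fluorophenyl nor 4-cyanophenyl can be told apart from methyl in this assay. Nothing available accounts for why the number stays within the scatter across these exchanges.

All the steps among the three compounds lie within the scatter, so these compounds do not show what would move the number at this position or on this nitrogen. From the compounds shown here alone, whether an amine or a carboxylic acid in place of cyano on the phenyl ring, or a longer chain on the amine nitrogen in a ring, would carry the number beyond the scatter remains open.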